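This account rests on a few compounds, and the source may have more. Where it says the series, first, only, none or still open, it means among the compounds named here.

In a functional assay on MCF7 cells (Homo sapiens) for inhibition, read by MTT assay, with a stated time of 72 h (a lower number here means a stronger inhibitor, a higher number a weaker inhibitor), compound 1 `C=C(Br)C(=O)Nc1cccc(/C=C/C(=O)Nc2ccc(OC)cc2)c1` gives 2500 nM, while compound 2 `C=C(Br)C(=O)Nc1cccc(/C=C/C(=O)Nc2ccc(OC(F)(F)F)cc2)c1` gives 43300 nM, the higher and therefore weaker of the only two results so far. Among the measured compounds shown here, the single measured step is a 17-fold higher number from compound 1 to compound 2 (1.24 log units; beyond the scatter), with trifluoromethyl in place of methyl on an oxygen on an aromatic ring. This step is large and beyond the scatter, showing that a change in this substituent can shift the result substantially.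

Compound 3 `C=C(Br)C(=O)Nc1cccc(/C=C/C(=O)Nc2ccc(SC(F)(F)F)cc2)c1` has not yet been measured in this assay. It carries (trifluoromethyl)sulfanyl in place of trifluoromethoxy on an aromatic carbon. The measured step is only a loose guide, since it replaced methyl with trifluoromethyl, whereas this change keeps the trifluoromethyl and swaps the oxygen for sulfur. For the measured compounds named here, no measured pair shows that swap, so the data give no firm direction. The expected change is therefore no step beyond the scatter, and the estimated step is a 1.2-fold lower number from compound 2 to compound 3 (0.09 log units; within the scatter). For compound 3, the estimate is 35000 nM, with an expected range from 9000 nM to 100000 nM.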

Compound 3, half-maximal inhibitory concentration: 30100 nM
For compound 3 the middle estimate is 1.2-fold (0.07 log units) above the measured one, within the range that was stated.
By their numbers in this assay, from the lowest: compound 1; then compounds 3 and 2 (each within the scatter of the next).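

Sulfur in place of oxygen between the ring and the trifluoromethyl group makes no readable difference at this position: in this assay the step is a 1.4-fold lower number from compound 2 to compound 3 (0.16 log units; within the scatter) and the trifluoromethoxy and (trifluoromethyl)sulfanyl groups cannot be told apart by this result. The second group confirms the gap seen earlier from a different direction, since the change from methoxy is also large, at a 12-fold higher number from compound 1 to compound 3 (1.08 log units; beyond the scatter) and compound 1 therefore remains the strongest inhibitor of the three, while both groups carrying a trifluoromethyl sit far from it and close to each other. Nothing measured here explains why this position tolerates the oxygen-to-sulfur exchange or why methoxy stands apart.

With only these three compounds, the link between trifluoromethyl and the weaker result cannot be separated from the particular linking atom, and methylsulfanyl, the sulfur partner of methoxy, would be the compound that tests this directly. The compounds shown also leave open how very different groups on the same aromatic carbon, such as an amine, a carboxylic acid or a longer alkoxy chain, would compare with methoxy.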